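Replacing the eight-membered ring on the sulfonyl sulfur

The source may report more compounds than this note shows. Statements on the series, on what has been measured and on what is new or still open speak of the compounds shown alone.

Three measured entries frame the series in an ADME assay on Vero cells (Chlorocebus sabaeus) for cytotoxicity, read by MTT assay; on this read-out higher numbers stand for lower toxicity in this test and lower numbers for higher toxicity in this test. Compound 1 `O=C(O)c1ccccc1-n1nc(C(F)(F)F)cc1C(=O)Nc1ccc(S(=O)(=O)N2CCCC2)cc1` has no number and is recorded as "not determined" (no result reported). Compound 2 `Cn1nc(C(F)(F)F)cc1C(=O)Nc1ccc(S(=O)(=O)N2CCCCCCC2)cc1` gives 16000 nM, the lower of the two numbers available. Compound 3 `Cn1nc(C(F)(F)F)cc1C(=O)Nc1ccc(S(=O)(=O)N2CCC[C@H]2C(=O)OC(=O)c2ccccc2)cc1` gives 100000 nM, a gap beyond the usual scatter.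

Compound 4 `Cn1nc(C(F)(F)F)cc1C(=O)Nc1ccc(S(=O)(=O)N2CCOCC2)cc1` has not yet been measured in this assay. It carries a single change from compound 2: a group of 6 heavy atoms (4 carbon, 1 nitrogen, 1 oxygen; one six-membered non-aromatic ring with 2 hetero atoms) in place of a group of 8 heavy atoms (7 carbon, 1 nitrogen; one eight-membered non-aromatic ring with 1 hetero atom), on a sulfonyl sulfur. Morpholin-4-yl therefore sits on the sulfonyl sulfur. Among the measured compounds shown here, no measured pair isolates this change, so the expectation rests on two numbers only: compound 2 at 16000 nM and compound 3 at 100000 nM. A move away from the low end is expected, towards less toxicity in this test and probably beyond the scatter, though short of the number for compound 3. The expected step is a 3.1-fold higher number from compound 2 to compound 4 (0.49 log units; beyond the scatter). Compound 4 is estimated at 50000 nM, with an expected range of 18000 nM to 150000 nM.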

Compound 4, half-maximal cytotoxic concentration: > 300000 nM
Compound 4: only a limit was reported; the forecaster's own chance of this, stated with the estimate: 25%; middle value at least 6.0-fold (0.77 log units) from the limit.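

Among the compounds shown here, on the sulfonyl sulfur, the group alone is enough to move the read-out in this assay: morpholin-4-yl in place of the eight-membered ring gives an at least 18-fold higher number from compound 2 to compound 4 (1.27 log units; beyond the scatter), the first step that isolates a single change. The result for compound 4 is a limit of the assay and not a number: the limit of > 300000 nM in this assay, at which 1 of the 4 values shown sits. Going by these compounds, the step therefore sets a floor on the size of this change, and its full size remains unknown.

The change swaps ring size and ring oxygen together, so the compounds shown cannot say which of the two goes with the step. A piperidin-1-yl group, with the six-membered ring but no oxygen, would separate them, and a piperazin-1-yl group would show whether a second ring nitrogen reads the same as the oxygen.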